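Amine terminus exchange on the cyclooctyl amide analogue

A few compounds are considered here, and "the series" means these few. Any claim that something is new, unique, unknown or untested is made for them only; others in the source may bear on it.

Compound 1 `CC(C)=CCC/C(C)=C/CC/C(C)=C/CSC[C@H](NC(=O)CCCCCN1CCN(C)CC1)C(=O)N1CCCC1` gives 6000 nM in a functional assay on MIA PaCa-2 cells (Homo sapiens) for cytotoxicity, read by fluorescence, with a stated time of 48 h; a lower number here means that less compound is needed, a higher number that more compound is needed for the effect. Within the data shown here, compound 2 `CC(C)=CCC/C(C)=C/CC/C(C)=C/CSC[C@H](NC(=O)CCCCCN1CCN(C)CC1)C(=O)N1CCCCC1` gives 14300 nM in this assay, the only single-point step in the set being a 2.4-fold higher number from compound 1 to compound 2 (0.38 log units; beyond the scatter). Compound 3 `CC(C)=CCC/C(C)=C/CC/C(C)=C/CSC[C@H](NC(=O)CCCCCN1CCCC1)C(=O)NC1CCCCCCC1` gives 1900 nM in this assay, the lowest of the three numbers, beyond the scatter from both compound 1 and compound 2. Compound 4 `CC(C)=CCC/C(C)=C/CC/C(C)=C/CSC[C@H](NC(=O)CCCCCN1CCN(C)CC1)C(=O)NC1CCCCCCC1` is not yet measured; it differs from compound 3 by 4-methylpiperazin-1-yl in place of pyrrolidin-1-yl on a saturated chain carbon, five bonds along the chain from a carbonyl carbon. Among the measured compounds shown here, no measured pair isolates this exchange: the step of a 2.4-fold higher number from compound 1 to compound 2 (0.38 log units; beyond the scatter) concerns the group on the carbonyl carbon and does not bear on it. Compound 1 and compound 2 carry the entering group yet score higher than compound 3, without a paired comparison. A step of a 1.4-fold higher number from compound 3 to compound 4 (0.14 log units; within the scatter) is expected, near the scatter. Compound 4 is estimated at 2600 nM, from 900 nM to 7500 nM.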

Compound 4, half-maximal effective concentration: 2500 nM
Beside the measured number, compound 4's estimate is 1.0-fold (0.02 log units) above it; the range from low to high includes it.
By their numbers in this assay, from the lowest: compounds 3 and 4 (each within the scatter of the next); then compound 1; then compound 2.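

In this assay the exchange of pyrrolidin-1-yl for 4-methylpiperazin-1-yl, on a saturated chain carbon, five bonds along the chain from a carbonyl carbon, is now isolated, with a 1.3-fold higher number from compound 3 to compound 4 (0.12 log units; within the scatter) leaving the two termini indistinguishable here. With 4-methylpiperazin-1-yl held constant, cyclooctylamino on the carbonyl carbon gives a 5.7-fold lower number from compound 2 to compound 4 (0.76 log units; beyond the scatter) against piperidin-1-yl and a 2.4-fold lower number from compound 1 to compound 4 (0.38 log units; beyond the scatter) against pyrrolidin-1-yl, so among these compounds the group on the carbonyl carbon moves the number while the terminus does not. No evidence bearing on this result is available.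

Open, on these data alone, is whether a morpholine or dimethylamino terminus, or a shorter or longer chain, would fit the same reading.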